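A few compounds are considered here, and "the series" means these few. Any claim that something is new, unique, unknown or untested is made for them only; others in the source may bear on it.

Measured so far in a functional assay on HaCaT cells (Homo sapiens) for cytotoxicity, with a stated time of 48 h; a lower number here means a stronger inhibitor, a higher number a weaker inhibitor:
compound 1 `COc1cc(OC)c(C(=O)/C=C/c2ccccc2OC)c(OC)c1` gives 8700 nM
compound 2 `COc1cc(OC)c(C(=O)/C=C/c2ccccc2SC)c(OC)c1` gives 7700 nM
compound 3 `COc1cc(O)c(C(=O)/C=C/c2ccccc2OC)c(OC)c1` gives 10900 nM

Compound 3 stands at 10900 nM and lies within the scatter of both compound 1 and compound 2, so the three measured values do not separate from one another.

Compound 4 `COc1cc(O)c(C(=O)/C=C/c2ccccc2SC)c(OC)c1` carries methylsulfanyl in place of methoxy on an aromatic carbon, ortho to a large group, as counted in methylsulfanyl in place of methoxy on an aromatic carbon and otherwise matches compound 3. The same exchange has been measured once, as a 1.1-fold lower number from compound 1 to compound 2 (0.05 log units; within the scatter) and it did not move the number beyond the scatter. The other measured step, a 1.3-fold higher number from compound 1 to compound 3 (0.10 log units; within the scatter) is the hydrogen in place of methyl on an oxygen on an aromatic ring that compound 3 already carries, and it also stays within the scatter. Whether the exchange behaves the same way on compound 3 has not been measured, and a single pair is thin support. Even so, no step beyond the scatter is expected in this assay and the estimate amounts to a 1.1-fold lower number from compound 3 to compound 4 (0.06 log units; within the scatter) at most a small one. For compound 4 the estimated value is 9600 nM with an expected range from 5500 nM to 17000 nM in this measurement.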

Compound 4, half-maximal inhibitory concentration: 10500 nM
For compound 4 the middle estimate is 1.1-fold (0.04 log units) below the measured one; measured number inside the range.
By their numbers in this assay, from the lowest: compounds 2, 1, 4 and 3 (each within the scatter of the next).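

In this assay, methylsulfanyl in place of methoxy on an aromatic carbon, ortho to a large group, has now been read on a second core, where it gives (a 1.0-fold lower number from compound 3 to compound 4 (0.02 log units; within the scatter)), and the two readings agree: the same change on two cores in this assay, a 1.1-fold lower number (0.05 log units; within the scatter) from compound 1 to compound 2 and a 1.0-fold lower number (0.02 log units; within the scatter) from compound 3 to compound 4, 1.1-fold (0.04 log units) apart, within the scatter of two such steps. The hydrogen in place of methyl on an oxygen on an aromatic ring has also been read a second time, now with methylsulfanyl in place, as (a 1.4-fold higher number from compound 2 to compound 4 (0.13 log units; within the scatter)), and it too repeats: the same change on two cores in this assay, a 1.3-fold higher number (0.10 log units; within the scatter) from compound 1 to compound 3 and a 1.4-fold higher number (0.13 log units; within the scatter) from compound 2 to compound 4, 1.1-fold (0.04 log units) apart, within the scatter of two such steps. Across these four compounds, neither change moves the number beyond the scatter, whichever form the other place takes, so the single earlier reading of each change now has a matching pair behind it.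

The compounds shown leave open whether any other group on this aromatic carbon, such as an amine, a chlorine atom or a longer ether chain like ethoxy, would move the number beyond the scatter. With all four values lying within the scatter of their neighbours, they also leave open which part of the structure the cytotoxicity in this assay responds to at all.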